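This account rests on a few compounds, and the source may have more. Where it says the series, first, only, none or still open, it means among the compounds named here.

Compound 2 `Cc1c(Nc2nc(N)c3c(C#N)c(N4CCC[C@H]4C)n(C)c3n2)cnn1CC1(O)COC1` gives 220 nM in an assay on HEK293 cells for inhibition of Leucine-rich repeat serine/threonine-protein kinase 2 (Homo sapiens), with a stated time of 48 h; a higher number here means a weaker inhibitor, a lower number a stronger inhibitor. Compound 1 `Cc1c(Nc2nc(N)c3c(C#N)c(N4CCC[C@H]4C)n(C)c3n2)cnn1[C@H]1CCOC1` gives 140 nM, and a 1.6-fold higher number from compound 1 to compound 2 (0.20 log units; within the scatter), so these two compounds cannot be told apart by this measurement. Compound 3 `Cc1c(Nc2nc(N)c3c(C#N)c(N4CCC[C@H]4C)n(C)c3n2)cnn1CC(C)(C)O` differs from compound 2 by 1-hydroxy-1-methylethyl in place of 3-hydroxyoxetan-3-yl on a saturated chain carbon bound to an aromatic nitrogen. Among the compounds with values here, the only measured step also swaps a group on an aromatic nitrogen and stayed within the scatter, so no shift beyond the scatter is expected for compound 3. The step expected from compound 2 to compound 3 is a 1.1-fold lower number from compound 2 to compound 3 (0.04 log units; within the scatter). Compound 3 is estimated to give about 200 nM in this assay, within a range of 90 nM to 450 nM.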

Compound 3, half-maximal inhibitory concentration: 280 nM
The estimate for compound 3 lay 1.4-fold (0.15 log units) below the measured number, and the stated range covers the measured number.
By their numbers in this assay, from the lowest: compounds 1, 2 and 3 (each within the scatter of the next).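

Swapping 3-hydroxyoxetan-3-yl for the open-chain 1-hydroxy-1-methylethyl on a saturated chain carbon bound to an aromatic nitrogen gives a 1.3-fold higher number from compound 2 to compound 3 (0.10 log units; within the scatter), so the four-membered ring can be removed with no change this measurement can detect. Placing 2-hydroxy-2-methylpropyl instead of oxolan-3-yl on the aromatic nitrogen gives a 2.0-fold higher number from compound 1 to compound 3 (0.30 log units; within the scatter), so all three groups shown remain indistinguishable here. No available evidence bears on the reason for this. Still open, going by these compounds, is whether an amine, a carboxylic acid or a longer chain on that aromatic nitrogen would move the number beyond the scatter.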